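Swapping a Benzyl for a Carbamoyl on an Inactive Core

The compounds below may be only part of what the source reports. "The series", "measured", "known", "first", "only" and "open" are said of these compounds alone.

Compound 2 `NC(=O)c1c(NC(=O)c2ccccc2Cl)sc2c1CCN(Cc1ccc(Cl)cc1)C2` is the starting point. In a functional assay on HeLa cells (Homo sapiens) for antiproliferative activity, with a stated time of 24 h (a lower number here means a stronger inhibitor, a higher number a weaker inhibitor), compound 2 gives > 50000 nM, which is a limit of the assay rather than a number. Compound 1 `Cc1ccccc1CN1CCc2c(sc(NC(=O)c3ccccc3Cl)c2C(N)=O)C1` is a close relative, and in this assay compound 1 gives > 50000 nM, again a limit. Compound 3 `NC(=O)c1c(NC(=O)c2ccc(C(F)(F)F)cc2)sc2c1CCN(Cc1ccc(Cl)cc1)C2` is another close relative, and in this assay compound 3 gives > 50000 nM, also a limit. Accordingly the steps a step that the two limits leave unreadable from compound 1 to compound 2 and a step that the two limits leave unreadable from compound 2 to compound 3 cannot be read, since (the limit of > 50000 nM in this assay, at which 3 of the 3 values shown sit). The new compound 4 `NC(=O)c1c(NC(=O)c2ccccc2Cl)sc2c1CCN(C(=O)Nc1ccccc1Cl)C2` carries (2-chlorophenyl)carbamoyl in place of 4-chlorobenzyl on an amine nitrogen in a ring. Neither measured step touches this change, and neither has a readable size, so there is no measured basis for a shift in either direction in this assay. Compound 4 is therefore estimated at 50000 nM, with a range from 15000 nM to 200000 nM, and most likely it will again be reported only as a limit. That corresponds to an expected step of a number no higher from compound 2 to compound 4 (the limit leaves the size open).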

Compound 4, half-maximal inhibitory concentration: 45400 nM
Compound 4: the middle estimate sits 1.1-fold (0.04 log units) above what was measured; the measured number falls inside the stated range.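

Going by these compounds alone, at this amine nitrogen in a ring, the (2-chlorophenyl)carbamoyl group gives the first value in this assay that is a number and not a limit, so compound 4 is the only compound here with a fixed position on the scale. Read as steps, the change gives an at least 1.1-fold lower number from compound 2 to compound 4 (0.04 log units; that floor lies within the scatter) and an at least 1.1-fold lower number from compound 1 to compound 4 (0.04 log units; that floor lies within the scatter) and so, with both floors inside the scatter, it cannot be called a real gain in strength. The steps among the three earlier compounds still cannot be read.

The compounds shown leave open whether this number depends on the carbamoyl link or on the chlorine of its phenyl ring. A plain phenylcarbamoyl, a methylcarbamoyl or an acetyl on the same nitrogen would be needed to tell these apart.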